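A 3-Fluorophenyl Amide Estimated from Three Measured Neighbours

The source may hold more compounds than are shown below. What is called first, only, known or untested is meant among the compounds shown, and "the series" means these compounds.

Compound 1 `CN1C[C@H](C(=O)Nc2ccccc2)[C@@H](c2ccc(/C=C/C(=O)Nc3ccccc3N)cc2)C1`: 7 mL/min/kg
Compound 2 `CN1C[C@H](C(=O)Nc2ccc(F)cc2)[C@@H](c2ccc(/C=C/C(=O)Nc3ccccc3N)cc2)C1`: 5 mL/min/kg
Compound 3 `CC(C)c1ccc(NC(=O)[C@H]2CN(C)C[C@@H]2c2ccc(/C=C/C(=O)Nc3ccccc3N)cc2)cc1`: 10 mL/min/kg

Measured in an in vitro ADME assay on microsomes from liver (Homo sapiens) for pharmacokinetics, read by LC-MS, with a stated time of 10 min, tested at 1 uM (on this read-out lower numbers stand for slow clearance and higher numbers for fast clearance), compound 3 returns the largest of the three numbers, yet a 1.4-fold higher number from compound 1 to compound 3 (0.15 log units; within the scatter) and a 2.0-fold higher number from compound 2 to compound 3 (0.30 log units; within the scatter) both sit inside the scatter, so no ordering among the three is secure. Compound 4 `CN1C[C@H](C(=O)Nc2cccc(F)c2)[C@@H](c2ccc(/C=C/C(=O)Nc3ccccc3N)cc2)C1` differs from compound 3 by 3-fluorophenyl in place of 4-isopropylphenyl on an amide-type nitrogen. Among the compounds with values here, three measured steps bear on this change: a 1.4-fold lower number from compound 1 to compound 2 (0.15 log units; within the scatter), a 1.4-fold higher number from compound 1 to compound 3 (0.15 log units; within the scatter) and a 2.0-fold higher number from compound 2 to compound 3 (0.30 log units; within the scatter); none moved the clearance number beyond the scatter. Compound 4 carries a fluorophenyl as does compound 2, which gives 5 mL/min/kg in this assay. Compound 4 is therefore expected to give 6 mL/min/kg, with a range of 3 mL/min/kg to 12 mL/min/kg. The implied step, a 1.7-fold lower number from compound 3 to compound 4 (0.22 log units; within the scatter), is expected to remain within the scatter.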

Compound 4, clearance: 6 mL/min/kg
Estimate against measurement, compound 4: no gap at the digits printed, and the stated range covers the measured number.
By their numbers in this assay, from the lowest: compounds 2, 4, 1 and 3 (each within the scatter of the next).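

In this assay, within the data shown here, the swap of 4-fluorophenyl for 3-fluorophenyl on the amide-type nitrogen stays within the scatter (a 1.2-fold higher number from compound 2 to compound 4 (0.08 log units; within the scatter)), so the place of the fluoro on this ring, which the earlier compounds did not vary, shows no readable effect. The other two new steps also stay within the scatter (a 1.2-fold lower number from compound 1 to compound 4 (0.07 log units; within the scatter); a 1.7-fold lower number from compound 3 to compound 4 (0.22 log units; within the scatter)), so all four amides remain unresolved. No measured evidence here accounts for these numbers. The compounds shown leave open whether a carboxylic acid or an amine on this ring would move the number beyond the scatter.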